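This account rests on a few compounds, and the source may have more. Where it says the series, first, only, none or still open, it means among the compounds named here.

Measured compounds:
- compound 1, `COc1cc(Cc2c[nH]c3ccccc23)c(N)c(OC)c1OC`: > 100000 nM
- compound 2, `COc1cc(Cc2c[nH]c3ccc(Cl)cc23)c(N)c(OC)c1OC`: "not active" (no number reported)

Of the compounds shown here, two sharing one core have been tested in a functional assay on HT-29 cells (Homo sapiens) for cytotoxicity, read by sulforhodamine B assay, with a stated time of 48 h; a lower number here means a stronger inhibitor of growth, a higher number a weaker inhibitor of growth. Compound 1 reaches only the limit of the assay, recorded as > 100000 nM, which is a limit and not a number. For compound 2 no number is given at all; in this assay compound 2 is reported as "not active" (no number reported). Compound 2 therefore stands without a measured value, next to a single other result that is itself a limit (the limit of > 100000 nM in this assay, at which 1 of the 2 values shown sits).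

Compound 3, `COc1cc(Cc2c[nH]c3ccc(Br)cc23)c(N)c(OC)c1OC`, follows from compound 2 by a single exchange: bromo in place of chloro on an aromatic carbon. Within the data shown here, since compound 2 offers no number to step from, no measured step can be stated. In this assay the expectation is a result of the same kind as for compound 2, with no change beyond the scatter. Compound 3 is therefore expected to give 200000 nM, most likely again only a limit, within 50000 nM to 1000000 nM.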

Compound 3, concentration for 50% growth inhibition: "not active" (no number reported)
No number was reported for compound 3, and the estimate cannot be compared.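

Compound 2 and compound 3 are both reported as "not active" with no number, so no step can be read between them. The compounds shown leave open whether any change to the shared core gives a measurable result in this assay.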